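A few compounds are considered here, and "the series" means these few. Any claim that something is new, unique, unknown or untested is made for them only; others in the source may bear on it.

Compound 3, `N=C(N)NCCC[C@@H](NC(=O)c1ccc2ccccc2n1)C(=O)NCc1ccc(C(F)(F)F)cc1`, shares its core with two measured companions and differs from them only in the aromatic group attached to the carbonyl carbon. In a functional assay on HEK293 cells for antagonist activity at melanin-concentrating hormone receptor 1 (Homo sapiens) (on this read-out higher numbers stand for weaker inhibition and lower numbers for stronger inhibition), compound 3 gives 904 nM. Its nearest neighbour on the numbers is compound 2, `N=C(N)NCCC[C@@H](NC(=O)c1ccnc2ccccc12)C(=O)NCc1ccc(C(F)(F)F)cc1`, which in this assay gives 1030 nM; compound 1, `COc1cccc2cc(C(=O)N[C@H](CCCNC(=N)N)C(=O)NCc3ccc(C(F)(F)F)cc3)oc12`, gives 622 nM. None of the three can be told apart on these figures: the steps between them are a 1.5-fold higher number from compound 1 to compound 3 (0.16 log units; within the scatter), a 1.1-fold lower number from compound 2 to compound 3 (0.06 log units; within the scatter) and a 1.7-fold higher number from compound 1 to compound 2 (0.22 log units; within the scatter), each within the scatter. Compound 4, `N=C(N)NCCC[C@@H](NC(=O)c1csc2ccccc12)C(=O)NCc1ccc(C(F)(F)F)cc1`, keeps the same core and makes the next exchange at the same place: 1-benzothiophen-3-yl in place of quinolin-2-yl on a carbonyl carbon. Every measured step at this position has swapped one bicyclic aromatic group for another and each has left the read-out within the scatter, so the expectation for compound 4 is again no step beyond the scatter, a 1.0-fold lower number from compound 3 to compound 4 (0.00 log units; within the scatter). Compound 4 is therefore estimated at 900 nM, with a range from 350 nM to 2300 nM.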

Compound 4, half-maximal inhibitory concentration: 952 nM
For compound 4 the middle estimate is 1.1-fold (0.02 log units) below the measured one; the range from low to high includes it.
By their numbers in this assay, from the lowest: compounds 1, 3, 4 and 2 (each within the scatter of the next).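

Within the data shown here, compound 4 brings sulfur to this position for the first time, with 1-benzothiophen-3-yl placing a five-membered aromatic ring with one hetero atom where quinolin-2-yl had a six-membered one, and in this assay this exchange gives a 1.1-fold higher number from compound 3 to compound 4 (0.02 log units; within the scatter) on the shared core. The same group gives a 1.1-fold lower number from compound 2 to compound 4 (0.03 log units; within the scatter) and a 1.5-fold higher number from compound 1 to compound 4 (0.18 log units; within the scatter), so these four bicyclic aromatic groups, carrying nitrogen, oxygen or sulfur, cannot be told apart on this read-out. Nothing measured here explains why they read alike.

On these data alone, it remains open whether the read-out would move with something other than a bicyclic aromatic group on the carbonyl carbon, such as a single phenyl ring, a longer alkyl chain, an amine or a carboxylic acid. As far as these compounds go, every comparison here also rests on one core, so whether the same holds on another core is unknown.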